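The compounds below may be only part of what the source reports. "The series", "measured", "known", "first", "only" and "open" are said of these compounds alone.

Series notes. Compound 1 `COc1ccc(-c2cn(/N=C/c3cc4cc(C)ccc4nc3Cl)c(N)n2)cc1` and compound 2 `Cc1ccc2nc(Cl)c(/C=N/n3cc(-c4ccc5ccccc5c4)nc3N)cc2c1` share one core and differ only in the aryl group carried on it. In a functional assay on DLD-1 cells (Homo sapiens) for cytotoxicity, read by MTT assay, with a stated time of 48 h (on this read-out higher numbers stand for weaker inhibition and lower numbers for stronger inhibition), compound 1 gives 25700 nM and compound 2 gives 10200 nM. Among the compounds with values here, compound 2 thus holds the lowest of the two numbers so far; the separation from compound 1 is a 2.5-fold lower number from compound 1 to compound 2 (0.40 log units; beyond the scatter), the only step measured to date. Compound 3 `Cc1ccc2nc(Cl)c(/C=N/n3cc(-c4cccs4)nc3N)cc2c1` has not been measured. Its change from compound 2 is thiophen-2-yl in place of naphthalen-2-yl on an aromatic carbon. Within the data shown here, the one measured step bears on it only loosely: that step exchanged 4-methoxyphenyl for naphthalen-2-yl at this position and gave a modest gain, and no step with a five-membered ring at this position exists. Since compound 2 gained over compound 1 on that step, the reverse direction, a somewhat higher number, is expected here, and the step from compound 2 to compound 3 is estimated at a 1.8-fold higher number from compound 2 to compound 3 (0.25 log units; within the scatter). The estimate for compound 3 in this assay is 18000 nM, with an expected range from 7000 nM to 45000 nM.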

Compound 3, half-maximal inhibitory concentration: 8990 nM
Beside the measured number, compound 3's estimate is 2.0-fold (0.30 log units) above it; low and high end bracket the measured number.
By their numbers in this assay, from the lowest: compounds 3 and 2 (each within the scatter of the next); then compound 1.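

At the aromatic carbon next to the ring nitrogen, the exchange of naphthalen-2-yl, with its 2 six-membered aromatic rings of carbon only, for thiophen-2-yl, one five-membered aromatic ring with 1 hetero atom, gives a 1.1-fold lower number from compound 2 to compound 3 (0.05 log units; within the scatter) in this assay, so this large change in the aryl group leaves the two compounds indistinguishable. Set against 4-methoxyphenyl, thiophen-2-yl gives a 2.9-fold lower number from compound 1 to compound 3 (0.46 log units; beyond the scatter), which leaves compound 1 as the only one of the three standing apart, and a five-membered ring now serves here as well as the larger naphthalen-2-yl. Nothing available explains this result.

Open, on these data alone, is whether plain phenyl would sit with compound 1 or with compounds 2 and 3, which would show whether the methoxy group sets compound 1 apart. Also open, as far as these compounds go, is how a non-aromatic group at this position, such as a morpholine or a short alkyl chain, would compare.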